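Chain length and antiproliferative potency in an aminofuranose series

This account rests on a few compounds, and the source may have more. Where it says the series, first, only, none or still open, it means among the compounds named here.

Compound 1 `CCCCCCCNC[C@@H]1OC[C@H](N)[C@@H]1O` is measured in a functional assay on B16-F10 cells (Mus musculus) for antiproliferative activity, read by MTT assay, with a stated time of 72 h; a higher number here means a weaker inhibitor, a lower number a stronger inhibitor; the value for compound 1, > 128000 nM, is a limit of the assay the limit of > 128000 nM in this assay, at which 1 of the 3 values shown sits, and not a number. In this assay compound 2 `CCCCCCCCCCCCNC[C@@H]1OC[C@H](N)[C@@H]1O` gives 10700 nM, and compound 3 `CCCCCCCCCNC[C@@H]1OC[C@H](N)[C@@H]1O` gives 55200 nM. The change pentyl in place of hydrogen on a saturated chain carbon, seven bonds along the chain from an amine nitrogen brought an at least 11-fold lower number from compound 1 to compound 2 (1.07 log units; beyond the scatter). The cores of compound 1 and compound 3 differ by ethyl in place of hydrogen on a saturated chain carbon, seven bonds along the chain from an amine nitrogen, and between the longer chains there is a 5.2-fold higher number from compound 2 to compound 3 (0.71 log units; beyond the scatter). Compound 4 `CCCCCCCCCCCCCCNC[C@@H]1OC[C@H](N)[C@@H]1O` carries the same kind of change, (pentyl in place of hydrogen on a saturated chain carbon, nine bonds along the chain from an amine nitrogen), but here nine bonds along the chain from the amine nitrogen rather than seven. Resting on an at least 11-fold lower number from compound 1 to compound 2 (1.07 log units; beyond the scatter) and a 5.2-fold higher number from compound 2 to compound 3 (0.71 log units; beyond the scatter), compound 4 is expected to show the step of an 11-fold lower number from compound 3 to compound 4 (1.04 log units; beyond the scatter). The estimate for compound 4 is 5000 nM, expected to lie between 1500 nM and 20000 nM.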

Compound 4, half-maximal inhibitory concentration: 14300 nM
Estimate against measurement, compound 4: 2.9-fold (0.46 log units) below; measured number inside the range.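

Notes on carrying the change: in this assay, pentyl in place of hydrogen still lowers the number at nine bonds along the chain, with a 3.9-fold lower number from compound 3 to compound 4 (0.59 log units; beyond the scatter), but the step does not keep its size from one core to the other: the same change on two cores in this assay, an at least 11-fold lower number (1.07 log units; beyond the scatter) from compound 1 to compound 2 and a 3.9-fold lower number (0.59 log units; beyond the scatter) from compound 3 to compound 4, at least 3.0-fold (0.49 log units) apart, beyond the scatter of two such steps

Ethyl in place of hydrogen likewise depends on the core, and on the longer chain it gives a 1.3-fold higher number from compound 2 to compound 4 (0.13 log units; within the scatter), which lies within the scatter: the same change on two cores in this assay, an at least 2.3-fold lower number (0.36 log units; beyond the scatter) from compound 1 to compound 3 and a 1.3-fold higher number (0.13 log units; within the scatter) from compound 2 to compound 4, at least 3.0-fold (0.49 log units) apart, beyond the scatter of two such steps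

The step of an at least 8.9-fold lower number from compound 1 to compound 4 (0.95 log units; beyond the scatter) shows only a bound, so the full size of any step from compound 1 is not shown, as compound 1 stands at a limit of the assay: the limit of > 128000 nM in this assay, at which 1 of the 4 values shown sits.

Open, on these data alone, is whether a chain longer than that of compound 4 keeps, gains or loses activity. Also open, as far as these compounds go, is how a chain ending in a hydroxyl or a carboxylic acid would read.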